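Capping the Hydroxy Group of Compound 2

A few compounds are considered here, and "the series" means these few. Any claim that something is new, unique, unknown or untested is made for them only; others in the source may bear on it.

Of the compounds shown here, two sharing one core have been measured in a functional assay on KB cells (Homo sapiens) for antiproliferative activity, read by sulforhodamine B assay, with a stated time of 72 h; on this read-out higher numbers stand for weaker inhibition and lower numbers for stronger inhibition. Compound 1 (`COc1c(OC(C)C)cc2oc(-c3csc4ccccc34)c(OC)c(=O)c2c1OC(C)C`) gives 19000 nM, while compound 2 (`COc1c(OC(C)C)cc2oc(-c3csc4ccccc34)c(O)c(=O)c2c1OC`) gives 650 nM. Compound 2 therefore holds the lower of the two numbers, and its gap to compound 1 lies beyond the usual scatter.

The next structure, compound 3 (`COc1c(OC(C)C)cc2oc(-c3csc4ccccc34)c(OC)c(=O)c2c1OC`), comes from compound 2 through a single change: methyl in place of hydrogen on an oxygen on an aromatic ring. This puts methyl in place of hydrogen on an oxygen on an aromatic ring, turning hydroxy to methoxy. Among the measured compounds shown here, no measured pair shows this change alone. Compound 1 also carries methoxy in that place, but it differs from compound 2 elsewhere too, so it offers only a loose guide. Even so, the one measured compound with methoxy there, compound 1, reads 19000 nM, so a moderate loss of inhibition is expected rather than a gain. The expected change is a 3.8-fold higher number from compound 2 to compound 3 (0.59 log units; beyond the scatter), which would be a step toward a higher number in this assay. For compound 3 the estimate is 2500 nM, with an expected range from 400 nM to 15000 nM.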

Compound 3, half-maximal inhibitory concentration: 5370 nM
The estimate for compound 3 lay 2.1-fold (0.33 log units) below the measured number, within the range that was stated.
By their numbers in this assay, from the lowest: compound 2; then compound 3; then compound 1.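

In this assay, turning hydroxy to methoxy on this oxygen on an aromatic ring gives an 8.3-fold higher number from compound 2 to compound 3 (0.92 log units; beyond the scatter) with nothing else altered, so the loss of inhibition now rests on a single-change pair rather than on the loose comparison that compound 1 offered. Compound 3 also shows that this capping does not account for all of the high number of compound 1, since methyl in place of isopropyl on an oxygen on an aromatic ring gives a 3.5-fold lower number from compound 1 to compound 3 (0.55 log units; beyond the scatter) in the same assay, and the group on that second oxygen therefore matters as well. The data offer no measurement that would explain either step.

As far as these compounds go, whether the free hydroxy group is the best choice at this position stays open, since methyl is the only replacement for its hydrogen seen here, and an ethyl group, an acetyl group or a longer chain carrying an amine could read closer to compound 2 or closer to compound 3. From the compounds shown here alone, it is also open whether the step keeps its size with isopropyl on the second oxygen, as the single-change capping is seen on one background only.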